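The compounds below may be only part of what the source reports. "The series", "measured", "known", "first", "only" and "open" are said of these compounds alone.

Measured compounds:
compound 1, `CCOC(=O)[C@@]1(C(=O)NCc2ccc(C)cc2)C[C@H]1c1cc(OC)c(OC)c(OC)c1`, 26400 nM
compound 2, `CCOC(=O)[C@@]1(C(=O)Nc2ccccc2)C[C@H]1c1cc(OC)c(OC)c(OC)c1`, 48700 nM

In a functional assay on QGY cells (Homo sapiens) for cytotoxicity, read by MTT assay, with a stated time of 48 h (a higher number here means a weaker inhibitor, a lower number a stronger inhibitor), compound 1 gives 26400 nM. Compound 1 holds the lowest of the two numbers; its nearest neighbour is compound 2, which gives 48700 nM, and the step of a 1.8-fold higher number from compound 1 to compound 2 (0.27 log units; within the scatter) is within the scatter, so the two compounds cannot be told apart on these numbers.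

Compound 3, `CCOC(=O)[C@]1(C(=O)NCc2ccc(C)cc2)C[C@@H]1c1cc(OC)c(OC)c(OC)c1`, has not been measured. It differs from compound 1 as follows: the two compounds have the same atoms and bonds and differ only in configuration as drawn: 2 of 2 stereo elements differ (all stereocentres are inverted: mirror images); a stereocentre at a saturated ring carbon is drawn S in compound 1 and R in compound 3; a stereocentre at a saturated ring carbon is drawn S in compound 1 and R in compound 3. For the measured compounds named here, no measured step changes configuration; the only step known, a 1.8-fold higher number from compound 1 to compound 2 (0.27 log units; within the scatter), swaps the group on the amide nitrogen and gives no guide to a mirror image. With nothing to lean on, the expectation for compound 3 is a number close to that of compound 1, with a wide range, and the expected step is a 1.1-fold higher number from compound 1 to compound 3 (0.06 log units; within the scatter). For compound 3 the estimate in this assay is 30000 nM, between 9000 nM and 100000 nM.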

Compound 3, half-maximal inhibitory concentration: > 100000 nM
Compound 3: only a limit was reported; the forecaster's own chance of this, stated with the estimate: 20%; at least 3.3-fold (0.52 log units) between middle value and limit.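

In this assay, the mirror-image change gives an at least 3.7-fold higher number from compound 1 to compound 3 (0.57 log units; beyond the scatter), so the drawn configuration at the two saturated ring carbons matters here, something the earlier step on the amide nitrogen could not show. For compound 3, the value > 100000 nM is a limit of the assay and not a number. The gap can be put down to configuration alone, with no other part of the structure involved, because of this: the fact that compounds 1 and 3 differ only in the configuration as drawn

The compounds shown leave open whether the configuration of compound 1 is also preferred with phenyl on the amide nitrogen, and what each of the two ring stereocentres contributes on its own. They also leave open how the number responds when the ethyl ester gives way to a carboxylic acid, in either configuration.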